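The source may report more compounds than this note shows. Statements on the series, on what has been measured and on what is new or still open speak of the compounds shown alone.

Three compounds have so far been measured in an ADME assay on BJ cells (Homo sapiens), read by MTT assay, with a stated time of 72 h; a higher number here means a weaker inhibitor, a lower number a stronger inhibitor:

Compound 1 `COc1ncnc2c1c(I)cn2[C@@H]1O[C@H](CO)[C@@H](O)[C@H]1O` gives 91000 nM.
Compound 2 `COc1ncnc2c1c(-c1ccsc1)cn2[C@@H]1O[C@H](CO)[C@@H](O)[C@H]1O` gives 64300 nM.
Compound 3 `COc1ncnc2c1c(-c1ccoc1)cn2[C@@H]1O[C@H](CO)[C@@H](O)[C@H]1O` gives 28800 nM.

Among these three numbers compound 2 stands second highest. Its nearest neighbour is compound 1, with a 1.4-fold lower number from compound 1 to compound 2 (0.15 log units; within the scatter), so the two cannot be told apart. Its furthest neighbour is compound 3, with a 2.2-fold lower number from compound 2 to compound 3 (0.35 log units; beyond the scatter). The remaining measured step, a 3.2-fold lower number from compound 1 to compound 3 (0.50 log units; beyond the scatter), is of the same modest kind.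

Compound 4 `CSc1ncnc2c1c(-c1ccsc1)cn2[C@@H]1O[C@H](CO)[C@@H](O)[C@H]1O` differs from compound 2 in one place: methylsulfanyl in place of methoxy on an aromatic carbon. None of the three measured steps bears on this change. Each of them exchanges iodo, thiophen-3-yl or furan-3-yl on an aromatic carbon, while the methoxy stays the same in compounds 1, 2 and 3. Among the compounds with values here, there is therefore no measured step from which a direction for the exchange of methoxy for methylsulfanyl could be read. The expectation for compound 4 is accordingly a step of a 1.0-fold lower number from compound 2 to compound 4 (0.00 log units; within the scatter), that is, none beyond the scatter. Compound 4 is estimated at 64000 nM in this assay, with a range from 25000 nM to 160000 nM.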

Compound 4, half-maximal inhibitory concentration: 95800 nM
The estimate for compound 4 lay 1.5-fold (0.18 log units) below the measured number; the range from low to high includes it.
By their numbers in this assay, from the lowest: compound 3; then compounds 2, 1 and 4 (each within the scatter of the next).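

Within the data shown here, the exchange of methoxy for methylsulfanyl on an aromatic carbon of the six-membered aromatic ring, next to the ring nitrogen, gives the first measured step at this position: in this assay there is a 1.5-fold higher number from compound 2 to compound 4 (0.17 log units; within the scatter) and so compound 2 and compound 4 cannot be told apart. The earlier steps shown here varied only iodo, thiophen-3-yl and furan-3-yl with the methoxy held constant, whereas this step holds thiophen-3-yl constant and shows that replacing the oxygen of the methoxy with the sulfur of methylsulfanyl, at an equal count of heavy atoms, leaves the number within the scatter in this assay. No measurement at hand offers an explanation for this result.

This single step leaves open whether the same exchange would also stay within the scatter with iodo or furan-3-yl on the shared core in place of thiophen-3-yl. It also leaves open how this position would respond to a group of another kind, such as an amine, or to a longer chain such as butylsulfanyl in place of methylsulfanyl.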